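The compounds below may be only part of what the source reports. "The series", "measured", "known", "first", "only" and "open" are said of these compounds alone.

Compound 1 `COc1ccc([C@@H]2[C@H](Oc3ccccc3)C(=O)N2c2cc(OC)c(OC)c(OC)c2)cc1[N+](=O)[O-]`; compound 2 `COc1ccc([C@@H]2[C@@H](Oc3ccccc3)C(=O)N2c2cc(OC)c(OC)c(OC)c2)cc1[N+](=O)[O-]`; compound 3 `CCOC(=O)/C=C/c1ccc([C@@H]2[C@H](Oc3ccccc3)C(=O)N2c2cc(OC)c(OC)c(OC)c2)cc1`.

In a functional assay on MCF7 cells (Homo sapiens) for antiproliferative activity, read by MTT assay, with stated times of 24 h and 72 h (on this read-out lower numbers stand for stronger inhibition and higher numbers for weaker inhibition), compound 1 gives 69000 nM, compound 2 gives 4100 nM, and compound 3 gives 87000 nM. Compound 1 stands second highest of the three numbers: compound 3 lies within the scatter of it, while compound 2 lies far below it, a change described by a 17-fold lower number from compound 1 to compound 2 (1.23 log units; beyond the scatter) that rests on (the fact that compounds 1 and 2 differ only in the configuration as drawn). Compound 4 `COc1cc(N2C(=O)[C@@H](Oc3ccccc3)[C@H]2c2ccc(O)c(O)c2)cc(OC)c1OC` differs from compound 1 by 3,4-dihydroxyphenyl in place of 4-methoxy-3-nitrophenyl on a saturated ring carbon. For the measured compounds named here, no measured step alters this group; compounds 1 and 3, which carry different groups on that saturated ring carbon, give numbers within the scatter of each other. Compound 4 is therefore expected to stay near compound 1, with a 1.4-fold lower number from compound 1 to compound 4 (0.14 log units; within the scatter). The estimate for compound 4 is 50000 nM, in the range 10000 nM to 150000 nM.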

Compound 4, half-maximal inhibitory concentration: 4500 nM
Estimate against measurement, compound 4: 11-fold (1.05 log units) above; measured number outside the range, below it.
By their numbers in this assay, from the lowest: compounds 2 and 4 (each within the scatter of the next); then compounds 1 and 3 (each within the scatter of the next).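

In this assay compounds 1 and 3, which carry different groups on this saturated ring carbon, gave numbers within the scatter of each other, so the position could have seemed indifferent to its group. With 3,4-dihydroxyphenyl in place of 4-methoxy-3-nitrophenyl there is a 15-fold lower number from compound 1 to compound 4 (1.19 log units; beyond the scatter), which shows that the position does respond to the group it carries. Nothing given here accounts for the size of this step.

As far as these compounds go, it stays open whether a single hydroxy group on the phenyl ring would be enough, or how an amino group would fare there. From the compounds shown here alone, it is also open whether the step would be the same in the configuration of compound 2.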